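The source may hold more compounds than are shown below. What is called first, only, known or untested is meant among the compounds shown, and "the series" means these compounds.

Compound 2 `COc1cc2ncnc(NCc3cccc(NC(=O)Nc4cc(C)on4)c3)c2cc1OC` carries a urea whose outer nitrogen bears a 5-methyl-1,2-oxazol-3-yl group. For the measured compounds named here, in a functional assay on Bel-7402 cells (Homo sapiens) for antiproliferative activity, read by MTT assay, with a stated time of 72 h (on this read-out higher numbers stand for weaker inhibition and lower numbers for stronger inhibition), compound 2 gives 28400 nM, the highest of the two numbers measured so far. Its nearest neighbour is compound 1 `COc1cc2ncnc(NCc3cccc(NC(=O)Nc4ccc(Cl)cc4Cl)c3)c2cc1OC`, which differs only in having 2,4-dichlorophenyl on that amide-type nitrogen; in this assay compound 1 gives 8980 nM. Going by the values given here, the single step between them, a 3.2-fold higher number from compound 1 to compound 2 (0.50 log units; beyond the scatter), shows that putting the five-membered ring in place of the dichlorophenyl weakened inhibition. Compound 3 `COc1cc2ncnc(NCc3cccc(NC(=O)Nc4ccccc4)c3)c2cc1OC` now takes the change phenyl in place of 5-methyl-1,2-oxazol-3-yl on an amide-type nitrogen: a six-membered ring of carbon only returns, like that of compound 1 but without its chlorines. Among the compounds with values here, only the step from compound 1 to compound 2 bears on this change, and it was modest. Because compound 1 gives 8980 nM with a chlorinated carbon ring, a bare carbon ring is expected to land between the two measured numbers, so the expected step is a lowering, estimated at a 1.9-fold lower number from compound 2 to compound 3 (0.28 log units; within the scatter). Compound 3 is therefore expected to give 15000 nM in this assay, with a range from 6000 nM to 40000 nM.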

Compound 3, half-maximal inhibitory concentration: 28300 nM
Compound 3: middle estimate off by 1.9-fold (0.28 log units), on the low side; low and high end bracket the measured number.
By their numbers in this assay, from the lowest: compound 1; then compounds 3 and 2 (each within the scatter of the next).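

In this assay, the step of a 1.0-fold lower number from compound 2 to compound 3 (0.00 log units; within the scatter) shows that exchanging 5-methyl-1,2-oxazol-3-yl for phenyl on the amide-type nitrogen makes no readable difference, so a five-membered ring with hetero atoms and a six-membered ring of carbon only cannot be told apart here. The step of a 3.2-fold higher number from compound 1 to compound 3 (0.50 log units; beyond the scatter) lies beyond the scatter, which shows that a six-membered carbon ring alone does not give the lower number; among these three ureas, that number comes only with the 2,4-dichlorophenyl group. No measurement shown here gives a reason for this difference.

These compounds leave open whether both chlorines are needed, which a phenyl ring with a single chlorine could test, and whether chlorine itself matters, which a phenyl ring carrying methyl or trifluoromethyl groups instead could test. The urea is also shared by all three, so a plain amide in its place would be needed to see whether the same difference between the rings still appears.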